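A few compounds are considered here, and "the series" means these few. Any claim that something is new, unique, unknown or untested is made for them only; others in the source may bear on it.

Measured so far:
- compound 1, `Oc1nc2nonc2nc1Nc1ccccc1F`, gives 12500 nM
- compound 2, `COc1cccc(Nc2nc3nonc3nc2O)c1`, gives 75400 nM
- compound 3, `CCCCCCCCNc1nc2nonc2nc1O`, gives 3400 nM

All three were tested in an assay on mitochondria from L6 cells (Rattus norvegicus) for activation, with a stated time of 90 min; on this read-out lower numbers stand for an effect already at smaller amounts and higher numbers for an effect only at larger amounts of compound. Compound 2 stands at the highest number of the three: compound 1 sits well below it, and compound 3, with its octyl chain in place of an aromatic ring, lies furthest below, both gaps beyond the usual scatter. Compound 4, `Oc1nc2nonc2nc1Nc1cccc(OC(F)(F)F)c1`, is the next member of the series and has not yet been measured in this assay. It differs from compound 2 in one place: trifluoromethyl in place of methyl on an oxygen on an aromatic ring. Within the data shown here, no measured pair shows this exact change, so no direct anchor exists for its effect. What the three numbers do show is that compound 2 is the least favourable starting point, and the substituted aromatic ring of compound 1 reaches a lower number than the methoxy-bearing ring of compound 2. On that basis a modest improvement for compound 4 is expected, the step of a 2.5-fold lower number from compound 2 to compound 4 (0.40 log units; beyond the scatter) being in the direction of a lower number but possibly within the scatter. Compound 4 is therefore estimated at 30000 nM, with a likely range from 8000 nM to 100000 nM.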

Compound 4, half-maximal effective concentration: 5100 nM
For compound 4 the middle estimate is 5.9-fold (0.77 log units) above the measured one; measured number outside the range, below it.
By their numbers in this assay, from the lowest: compounds 3 and 4 (each within the scatter of the next); then compound 1; then compound 2.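

Replacing methyl with trifluoromethyl on the oxygen on the aromatic ring gives, in this assay, a 15-fold lower number from compound 2 to compound 4 (1.17 log units; beyond the scatter), a large step. Among these compounds, this is the first pair that differs in one place, so it is the first result that ties a change in the number to a single group rather than to several differences at once. It shows that what sits on this oxygen matters strongly, though no measurement at hand explains why the number moves.

As far as these compounds go, whether an ethyl group on the same oxygen, or a hydroxyl or a chlorine in place of the whole methoxy group, would shift the number in the same way remains open. A single pair also cannot show whether this change would have a similar effect in other compounds of the series.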